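The compounds below may be only part of what the source reports. "The series", "measured", "known", "first", "only" and "open" are said of these compounds alone.

Measured so far in a physicochemical assay for lipophilicity, measured as octanol-water partition; a higher number here means a more lipophilic compound, a lower number a more polar compound:
compound 1 `N#Cc1c(-c2ccco2)[n+]([O-])c2ccccc2[n+]1[O-]`: 0.582
compound 2 `COc1ccc2c(c1)[n+]([O-])c(C#N)c(-c1ccco1)[n+]2[O-]`: 0.354

Compound 2 stands level with compound 1 in this assay. For the measured compounds named here, the only measured step between them is a number 0.23 log units lower from compound 1 to compound 2 (within the scatter), and it came with methoxy in place of hydrogen on an aromatic carbon.

Compound 3 `COc1ccc2c(c1)[n+]([O-])c(C#N)c(-c1cccs1)[n+]2[O-]` has not been measured yet. It keeps the methoxy group of compound 2 but carries thiophen-2-yl in place of furan-2-yl on an aromatic carbon. Going by the values given here, the one measured step concerns another group, so it offers little guidance, and no measured pair covers this swap. The two rings match in size, with sulfur entering where oxygen leaves. A modest rise in this assay is expected, though with a wide margin. The expected change is a number 0.40 log units higher from compound 2 to compound 3 (beyond the scatter). For compound 3 the estimated value is 0.75, with an expected range from 0.35 to 1.15.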

Compound 3, partition coefficient: 1.11
For compound 3 the middle estimate is 0.36 log units below the measured one; measured number inside the range.
By their numbers in this assay, from the lowest: compounds 2 and 1 (each within the scatter of the next); then compound 3.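

For the compounds shown here, at the position next to the ring nitrogen, the earlier compounds showed nothing about changing the attached ring, and the only step they offered, at the methoxy group, stayed within the scatter. In this assay, thiophen-2-yl in place of furan-2-yl gives a number 0.76 log units higher from compound 2 to compound 3 (beyond the scatter), so exchanging one oxygen for one sulfur, with the ring size and the heavy-atom count unchanged, is enough to move the number clearly. No measurement available here explains why this swap has an effect of this size.

From the compounds shown here alone, whether the same swap would give a similar step on the core of compound 1, without the methoxy group, remains open. Also open, going by these compounds, is how the number would respond at this position to a phenyl ring, an amine or a carboxylic acid.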